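The source may report more compounds than this note shows. Statements on the series, on what has been measured and on what is new or still open speak of the compounds shown alone.

- Compound 1 `O=C1OC(Cc2nc(-c3ccc(Oc4ccccc4)cc3)no2)c2ccccc21`: > 10000 nM
- Compound 2 `COc1cc(OC)c2c(c1)C(C(O)c1ccc(O)cc1)OC2=O`: > 10000 nM

In a functional assay on RAW264.7 cells (Mus musculus) for inhibition, read by Griess assay, with stated times of 1 h and 24 h (a lower number here means a stronger inhibitor, a higher number a weaker inhibitor), compound 2 gives > 10000 nM, which is a limit of the assay and not a number. Compound 1 gives > 10000 nM, and this too is only a limit. The position of compound 2 is therefore not fixed by a number, and the record so far amounts to the limit of > 10000 nM in this assay, at which 2 of the 2 values shown sit.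

Compound 3 `CCCCCCOc1ccc(C(O)C2OC(=O)c3c(OC)cc(OC)cc32)cc1` has not yet been measured. It differs from compound 2 by one change, hexyl in place of hydrogen on an oxygen on an aromatic ring, or hydroxy to hexyloxy: hexyl in place of hydrogen on an oxygen on an aromatic ring.

Within the data shown here, no measured pair shows what such a change does, so any expectation here is loose. A modest gain in inhibition is expected in this assay, and the estimated size and direction are an at least 1.4-fold lower number from compound 2 to compound 3 (0.15 log units; that floor lies within the scatter). There is also a real chance that the new compound will again give only a limit. For compound 3, the expected value is 7000 nM, within an estimated range of 1500 nM to 20000 nM.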

Compound 3, half-maximal inhibitory concentration: 5360 nM
The estimate for compound 3 lay 1.3-fold (0.12 log units) above the measured number, within the range that was stated.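

With hexyl in place of hydrogen on an oxygen on an aromatic ring, compound 3 gives 5360 nM in this assay, the first result in this series that is a number and not a limit. The limit of compound 2 means that the change of hydroxy to hexyloxy can be stated only as a floor, an at least 1.8-fold lower number from compound 2 to compound 3 (0.27 log units; that floor lies within the scatter), and the real gap may be larger than that floor. The result shows that this oxygen need not carry hydrogen for a numerical value to appear, although the record as a whole still rests largely on one boundary: the limit of > 10000 nM in this assay, at which 2 of the 3 values shown sit.

Going by these compounds, what remains open is whether the step depends on the hexyl chain in particular: a methyl group, a longer chain such as decyl, or a chain ending in an amine or a carboxylic acid would test this at the same oxygen. A single step also leaves open whether hexyl on this oxygen would have a similar effect on any core other than the one shared by these two compounds.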